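A few compounds are considered here, and "the series" means these few. Any claim that something is new, unique, unknown or untested is made for them only; others in the source may bear on it.

Of the compounds shown here, two sharing one core have been measured in an assay on IMR-32 cells for displacement of a labelled ligand from corticotropin-releasing factor receptor 1 (Homo sapiens), read by scintillation counting, with a stated time of 2 h; on this read-out lower numbers stand for stronger inhibition and higher numbers for weaker inhibition. Compound 1 `CCc1nc(-c2ccc(OC(F)(F)F)cc2OC)c(CC)nc1NC(CC)CC` gives 7.2 nM in this assay. Among the compounds with values here, compound 2 `CCc1nc(N(CC2CC2)CC2CC2)c(CC)nc1-c1ccc(Cl)cc1Cl` gives 26 nM in this assay, the higher of the two numbers; the gap to compound 1, its only neighbour, lies beyond the usual scatter, so compound 2 is the weaker binder of the pair. Within the data shown here, the two differ in several places at once, so no single structural step links them.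

Compound 3 `CCCN(CCN(C)C)c1nc(CC)c(-c2ccc(Cl)cc2Cl)nc1CC` is built from compound 2 by one change: (2-(dimethylamino)ethyl)(propyl)amino in place of bis(cyclopropylmethyl)amino on an aromatic carbon. Among the measured compounds shown here, no measured pair shows this kind of exchange, so there is no step to lean on, and the expectation rests on compound 2 alone. He expects the step from compound 2 to compound 3 a 1.5-fold higher number from compound 2 to compound 3 (0.19 log units; within the scatter) to be modest, most likely within the scatter, with at best a slight lean toward a weaker number. Compound 3 is accordingly estimated at 40 nM in this assay, with a range from 10 nM to 160 nM.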

Compound 3, inhibition constant: 1540 nM
The estimate for compound 3 lay 39-fold (1.59 log units) below the measured number, and the stated range ends below it.
By their numbers in this assay, from the lowest: compound 1; then compound 2; then compound 3.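

In this assay, within the data shown here, putting (2-(dimethylamino)ethyl)(propyl)amino in place of bis(cyclopropylmethyl)amino on this aromatic carbon gives a 59-fold higher number from compound 2 to compound 3 (1.77 log units; beyond the scatter), the first single-place step and a large one. Both groups have 9 heavy atoms, so this position does not treat groups of equal heavy-atom count alike, and the number read here depends strongly on what the group is made of. The exchange removes both three-membered rings and brings in a second nitrogen in the same step, and nothing measured here separates these two changes or explains the large rise in the number.

A group such as dipropylamino, which has neither the rings nor the second nitrogen, would help to show which of the two changes carries the step, and a shorter chain ending in a hydroxyl or a morpholine ring would test other forms of the added heteroatom. From the compounds shown here alone, it also remains open whether the (2-(dimethylamino)ethyl)(propyl)amino group would give a step of similar size on a compound carrying a different aryl group in place of 2,4-dichlorophenyl.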